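This account rests on a few compounds, and the source may have more. Where it says the series, first, only, none or still open, it means among the compounds named here.

Measured compounds:
- compound 1 `C[Se]c1nc(N)c2ccccc2n1`: in a functional assay on HTB-54 cells (Homo sapiens) for cytotoxicity, read by MTT assay, with a stated time of 72 h (a lower number here means a stronger inhibitor of growth, a higher number a weaker inhibitor of growth), compound 1 gives 18000 nM
- compound 2 `CSc1nc(NCCCCCO)c2cccnc2n1`: compound 2 shows only a limit of the assay, > 100000 nM
- compound 3 `C[Se]c1nc([Se]C)c2ccccc2n1`: compound 3 gives 26600 nM

For the measured compounds named here, compound 1 sits together with compound 3 inside the usual scatter; the one computed step, a 1.5-fold higher number from compound 1 to compound 3 (0.17 log units; within the scatter), does not leave it. Compound 2 contributes no number, only (the limit of > 100000 nM in this assay, at which 1 of the 3 values shown sits).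

Compound 4 `CCCCC[Se]c1nc(N)c2ccccc2n1` differs from compound 1 by butyl in place of hydrogen on a saturated chain carbon bound to a selenium atom. Going by the values given here, no measured step lengthens the chain on selenium; the step of a 1.5-fold higher number from compound 1 to compound 3 (0.17 log units; within the scatter) changes a different position and stayed flat, so it offers no directional lead. The working expectation is therefore a step no larger than the scatter, direction open, and compound 4 is estimated at 15000 nM with a range of 4000 nM to 60000 nM. The expected step is a 1.2-fold lower number from compound 1 to compound 4 (0.08 log units; within the scatter).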

Compound 4, concentration for 50% growth inhibition: 34600 nM
For compound 4 the middle estimate is 2.3-fold (0.36 log units) below the measured one; the measured number falls inside the stated range.
By their numbers in this assay, from the lowest: compounds 1, 3 and 4 (each within the scatter of the next). At a limit, above all of these: compound 2.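

In this assay, for the compounds shown here, the first measured change at this position, on a saturated chain carbon bound to a selenium atom, gives a 1.9-fold higher number from compound 1 to compound 4 (0.28 log units; within the scatter). Going from methyl to pentyl on selenium therefore leaves the number inside the scatter, so this position accepts the added butyl without a readable change in growth inhibition. Nothing measured in this series bears on why the step stays this small.

On these data alone, whether a longer chain, a benzyl group or a chain carrying a carboxylic acid at this position would move the number beyond the scatter remains open.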